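The source may report more compounds than this note shows. Statements on the series, on what has been measured and on what is new or still open speak of the compounds shown alone.

Working notes on the series in a physicochemical assay for solubility, read by nephelometry, measured as kinetic solubility, at pH 2; a higher number here means a more soluble compound, a lower number a less soluble compound. Compound 1 (`N#Cc1ccc(NC(=O)Nc2ccnc(C(F)(F)F)c2)cc1`) gives 1.6 ug/mL. Compound 2 (`O=C(Nc1ccc(F)c(C(F)(F)F)c1)Nc1cnccn1`) gives 1.6 ug/mL, level with compound 1 at the digits reported and so within the scatter of it. These two compounds differ in more than one place, so they offer no measured single change to work from.

Compound 3 (`O=C(Nc1cccnc1)Nc1ccc(F)c(C(F)(F)F)c1`) has not yet been measured. It carries pyridin-3-yl in place of pyrazin-2-yl on an amide-type nitrogen. Within the data shown here, with no measured step to draw on, the expectation rests on this structural change alone and remains loose. A moderate rise beyond the scatter is expected, though a result level with compound 2 remains possible. The expected change is a 3.8-fold higher number from compound 2 to compound 3 (0.57 log units; beyond the scatter). In this assay, compound 3 is estimated at 6 ug/mL, with an expected range of 1.6 ug/mL to 30 ug/mL.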

Compound 3, solubility: 50 ug/mL
Compound 3: middle estimate off by 8.3-fold (0.92 log units), on the low side; the measured number lies above the stated range.
By their numbers in this assay, from the lowest: compounds 1 and 2 (each within the scatter of the next); then compound 3.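

In this assay, among these compounds, pyridin-3-yl in place of pyrazin-2-yl on an amide-type nitrogen gives a 31-fold higher number from compound 2 to compound 3 (1.49 log units; beyond the scatter) and provides the first measured single change. This place is therefore not silent: exchanging one six-membered aromatic ring for another, with the rest of compound 2 unchanged, moves the number well beyond the scatter. No measurement at hand bears on the reason for this step.

On these data alone, with a single step at this place, it remains open whether other groups there, such as pyrimidin-5-yl or a ring carrying an amine, would give a similar number. As far as these compounds go, it also remains open whether the same exchange would have a step of similar size on the core of compound 1.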